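Difluorophenyl Ketone in Place of a Methyl Ketone

A few compounds are considered here, and "the series" means these few. Any claim that something is new, unique, unknown or untested is made for them only; others in the source may bear on it.

Of the compounds shown here, three have been measured so far in an assay on isolated protein for binding affinity to histamine H2 receptor (Homo sapiens); a lower number here means a stronger inhibitor, a higher number a weaker inhibitor. Compound 1 `CCCCCC(=O)c1ccc(OCCCN2CCNCC2)cc1` gives 14500 nM. Compound 2 `CCCCCC(=O)c1ccc(OCCCN2CCN(S(=O)(=O)c3ccc(C#N)cc3)CC2)cc1` gives 12300 nM. Among the compounds with values here, the only single-point step among them is a 1.2-fold lower number from compound 1 to compound 2 (0.07 log units; within the scatter), and it shows that a (4-cyanophenyl)sulfonyl group on the ring amine changes little. Compound 3 `CCOC(=O)N1CCN(CCCOc2ccc(C(C)=O)cc2)CC1` gives 39800 nM, the highest of the three numbers; its gap to compound 1 and to compound 2 is beyond the scatter in both cases, so compound 3 is the weakest binder of the three.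

Compound 4 `CCOC(=O)N1CCN(CCCOc2ccc(C(=O)c3cccc(F)c3F)cc2)CC1` has not yet been measured. It differs from compound 3 by 2,3-difluorophenyl in place of methyl on a carbonyl carbon. Within the data shown here, no measured step touches this carbonyl: the one step known alters the ring amine instead and lies within the scatter, so it offers no guide here. Compound 1 and compound 2 differ from compound 3 in more than one place at once, so their lower numbers are only a loose hint that a larger group on the carbonyl may be tolerated or helpful. The expected step of a 2.7-fold lower number from compound 3 to compound 4 (0.42 log units; beyond the scatter) is therefore a modest move toward a lower number, with wide uncertainty. Compound 4 is estimated at 15000 nM, in a range from 4000 nM to 50000 nM.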

Compound 4, inhibition constant: 17400 nM
For compound 4 the middle estimate is 1.2-fold (0.06 log units) below the measured one, within the range that was stated.
By their numbers in this assay, from the lowest: compounds 2, 1 and 4 (each within the scatter of the next); then compound 3.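

Within the data shown here, replacing methyl with 2,3-difluorophenyl on the carbonyl carbon gives the first measured change at this position in this assay (a 2.3-fold lower number from compound 3 to compound 4 (0.36 log units; beyond the scatter)), and unlike the change on the ring amine (a 1.2-fold lower number from compound 1 to compound 2 (0.07 log units; within the scatter)), it lies beyond the scatter. The step is modest, but it shows that this carbonyl carbon can carry a group of 8 heavy atoms with an aromatic ring in place of a single carbon, and the number falls rather than rises. Nothing available here speaks to the reason for this shift.

Among these compounds, the single step changes two things at once, adding an aromatic ring and adding two fluorine atoms, so the share of each remains unknown; an unsubstituted phenyl on the same carbonyl would separate them, while a cyclohexyl would test whether the ring needs to be aromatic at all. From the compounds shown here alone, it also remains open whether 2,3-difluorophenyl would give a similar step on a core whose ring amine carries something other than the ethyl ester group kept in these two compounds.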